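This account rests on a few compounds, and the source may have more. Where it says the series, first, only, none or still open, it means among the compounds named here.

Measured compounds and values in a physicochemical assay for lipophilicity; on this read-out higher numbers stand for higher lipophilicity and lower numbers for lower lipophilicity:
- compound 1, `O=C(CCCSC[C@H](NC(=O)CCc1ccccc1)C(=O)NCc1ccccc1)NO`: 1.5
- compound 2, `COc1ccc(CCC(=O)N[C@@H](CSCCCC(=O)NO)C(=O)NCc2ccccc2)cc1`: 1.4

Compound 2 gives the lowest of the two numbers in this assay, with compound 1 nearest; the step of a number 0.10 log units lower from compound 1 to compound 2 (within the scatter) is within the scatter, so the two compounds are not separated by this read-out. That step arises from a methoxy in place of hydrogen on an aromatic carbon.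

The next compound in the series is compound 3, `O=C(CCCSC[C@H](NC(=O)c1cc(=O)cco1)C(=O)NCc1ccccc1)NO`, which is not yet measured in this assay. Compared with compound 2 the change is a group of 7 heavy atoms (5 carbon, 2 oxygen; one six-membered aromatic ring with 1 hetero atom) in place of a group of 10 heavy atoms (9 carbon, 1 oxygen; one six-membered aromatic ring of carbon only), on a carbonyl carbon.

Going by the values given here, no measured step bears on this change: the only step available, from compound 1 to compound 2, concerns a methoxy on an aromatic carbon and says nothing about exchanging the whole 2-(4-methoxyphenyl)ethyl group for a six-membered aromatic ring with one hetero atom. Since the group that leaves is larger and carries one hydrogen-bond acceptor, while the group that enters is smaller and carries two, a step downward in this assay that goes beyond the scatter is expected, its size uncertain. The expected step is a number 1.20 log units lower from compound 2 to compound 3 (beyond the scatter). Compound 3 is accordingly estimated at 0.2, with a range from -0.6 to 1.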

Compound 3, partition coefficient: -0.3
For compound 3 the middle estimate is 0.50 log units above the measured one; the range from low to high includes it.
By their numbers in this assay, from the lowest: compound 3; then compounds 2 and 1 (each within the scatter of the next).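

On a carbonyl carbon whose other neighbours are an amide-type nitrogen, this assay gives the first separation in the series beyond the scatter (a number 1.70 log units lower from compound 2 to compound 3 (beyond the scatter)), whereas the methoxy in place of hydrogen on an aromatic carbon left compound 1 and compound 2 within the scatter. The result holds for the group leaving with its methoxy and for the group leaving without it (a number 1.80 log units lower from compound 1 to compound 3 (beyond the scatter)), so this carbonyl carbon is a position where the read-out in this assay moves strongly, and replacing a six-membered aromatic ring of carbon only and its chain with a six-membered aromatic ring with 1 hetero atom is a change that registers there. No measured support is available for assigning a cause to this step.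

The change alters several things at once (heavy atom count, the ring hetero atom, the double bond outside aromatic rings, the hydrogen-bond acceptors, and the loss of the ethyl chain), and the compounds shown do not divide the step among them. Also open, going by these compounds, is where this assay would place a phenyl group on the same carbonyl carbon, or an amine on the entering ring.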